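A few compounds are considered here, and "the series" means these few. Any claim that something is new, unique, unknown or untested is made for them only; others in the source may bear on it.

In a functional assay on HepG2 cells (Homo sapiens) for antiproliferative activity, read by sulforhodamine B assay, with a stated time of 48 h (a lower number here means a stronger inhibitor, a higher number a weaker inhibitor), compound 1 (`c1ccc(CSc2nc(-c3cc4ccccc4[nH]3)nn2Cc2ccccc2)cc1`) gives 17.9 ug/mL, and compound 2 (`c1ccc(CSc2nc(-c3cc4ccccc4[nH]3)n(Cc3ccccc3)n2)cc1`) gives 16.3 ug/mL. These two values lie within the scatter of each other, so compound 1 stands level with compound 2 and the pair cannot be ranked. Among the compounds with values here, no step between measured compounds is available, which leaves the data without a direct guide to any single structural change.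

Compound 3 (`OCCn1nc(-c2cc3ccccc3[nH]2)nc1SCc1ccccc1`) departs from compound 1 at one place: hydroxymethyl in place of phenyl on a saturated chain carbon bound to an aromatic nitrogen. In words, hydroxymethyl stands in place of phenyl on a saturated chain carbon bound to an aromatic nitrogen, and the same difference, cut one bond further out, reads benzyl to 2-hydroxyethyl. Within the data shown here, nothing measured so far shows what this change does in this assay, so the expectation is only a judgement and remains loose. A modest move toward weaker inhibition seems more likely than a gain, although a result within the scatter would fit equally well. The estimated step is a 1.5-fold higher number from compound 1 to compound 3 (0.16 log units; within the scatter). For compound 3 the expected value is 26 ug/mL, with an estimated range from 11 ug/mL to 60 ug/mL.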

Compound 3, half-maximal inhibitory concentration: 12.1 ug/mL
Compound 3: middle estimate off by 2.1-fold (0.33 log units), on the high side, and the stated range covers the measured number.
By their numbers in this assay, from the lowest: compounds 3, 2 and 1 (each within the scatter of the next).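

In this assay, the exchange of hydroxymethyl for phenyl on a saturated chain carbon bound to an aromatic nitrogen gives a step (a 1.5-fold lower number from compound 1 to compound 3 (0.17 log units; within the scatter)) that stays inside the usual scatter, so compound 3 cannot be ranked against compound 1. Within the data shown here, this is the first reading at this position, and it shows that the benzyl group can give way to 2-hydroxyethyl without a change that can be told from the scatter, even though a six-membered aromatic ring of carbon leaves and a hydrogen-bond donor and acceptor enter. The phenyl ring at this place is therefore not needed to keep the activity at this level in this assay, but no reason for that outcome can be given from the data at hand.

As far as these compounds go, it remains open whether the hydroxyl itself contributes anything, which a plain ethyl group at the same place would test. An amine, a carboxylic acid or a longer chain ending in hydroxyl would show whether this position stays as permissive with other groups, or whether a step beyond the scatter can be found there.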